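The compounds below may be only part of what the source reports. "The series", "measured", "known", "first", "only" and "open" are said of these compounds alone.

Measured so far, in a functional assay on the whole organism for inhibition, with Mus musculus as the target, with a stated time of 2 h, at a dose of 50 mg/kg by the oral route; on this read-out higher numbers stand for more inhibition at the one dose given (going by the name of the read-out) and lower numbers for less inhibition:
- compound 1, `Cc1ccc(-c2c(S(=O)(=O)c3ccccc3)cnc3cc(C)nn23)cc1`, gives 25.2%
- compound 2, `Cc1ccc(-c2c(S(=O)(=O)c3ccccc3)cnc3ncnn23)cc1`, gives 5.2%
- compound 3, `Cc1ccc(-c2c(S(=O)(=O)c3ccccc3)cnc3c(Br)c(-c4ccccc4)nn23)cc1`, gives 61%

Compound 3 stands highest of the three numbers in this assay, beyond the scatter above compound 1 and further still above compound 2. The step to compound 4, `Cc1ccc(-c2c(S(=O)(=O)c3ccccc3)cnc3cc(-c4ccccc4)nn23)cc1`, is hydrogen in place of bromo on an aromatic carbon: bromo leaves, hydrogen enters, on the five-membered aromatic ring of the fused system. Going by the values given here, no measured pair isolates this change; compound 1 lacks the bromo but also carries methyl where compound 3 and compound 4 carry phenyl, so its lower number cannot be assigned to the bromo alone. A moderate drop is expected, the step of a number 16 percentage points lower from compound 3 to compound 4 (beyond the scatter) possibly within the scatter. Compound 4 is estimated at 45%, within 25% to 65%.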

Compound 4, a percentage reported as inhibition, in the whole organism at one dose (the size of the read-out at that dose, not a potency): 41%
Beside the measured number, compound 4's estimate is 4 percentage points above it; the range from low to high includes it.
By their numbers in this assay, from the lowest: compound 2; then compound 1; then compound 4; then compound 3.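

In this assay, going by these compounds alone, hydrogen in place of bromo on an aromatic carbon gives a number 20 percentage points lower from compound 3 to compound 4 (beyond the scatter), the first reading of the bromo as a single change, and it shows that the bromo counts on this read-out. Phenyl in place of methyl on an aromatic carbon gives a number 15.8 percentage points higher from compound 1 to compound 4 (beyond the scatter), so the phenyl also counts by itself, with a step of similar size. Nothing available explains either step.

From the compounds shown here alone, what an amine or chloro would give in place of the bromo remains open. So does whether a longer alkyl chain in place of the phenyl would hold the number.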